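Isopropyl replaces chlorobutyl on the amide of compound 3

The source may report more compounds than this note shows. Statements on the series, on what has been measured and on what is new or still open speak of the compounds shown alone.

Compound 1, `C/C=C/C(=O)N(Cc1cc(OC)c(OC)c(OC)c1)c1ccc(OC)c(O)c1`: in a functional assay on HCT-116 cells (Homo sapiens) for inhibition, read by MTT assay, with a stated time of 48 h (a lower number here means a stronger inhibitor, a higher number a weaker inhibitor), compound 1 gives 8450 nM.
Compound 2, `COc1ccc(CNc2cc(OC)c(OC)c(OC)c2)cc1[N+](=O)[O-]`: in this assay compound 2 gives 18200 nM.
Compound 3, `COc1ccc(CN(C(=O)CCCCCl)c2cc(OC)c(OC)c(OC)c2)cc1O`: in this assay compound 3 gives 220 nM.

Compound 3 holds the lowest number of the three, and its gaps to compound 1 and to compound 2 both lie beyond the scatter. Compound 4, `COc1ccc(CN(C(=O)C(C)C)c2cc(OC)c(OC)c(OC)c2)cc1O`, has not yet been measured. It differs from compound 3 in one place: isopropyl in place of 4-chlorobutyl on a carbonyl carbon. Within the data shown here, no pair of measured compounds shows this kind of change, so the direction of the step is uncertain. In this assay a modest weakening, beyond the scatter but far short of the gap separating compound 3 from compound 1, is expected from compound 3 to compound 4, a 2.7-fold higher number from compound 3 to compound 4 (0.44 log units; beyond the scatter). For compound 4 the expected value is 600 nM, with a range from 150 nM to 3000 nM.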

Compound 4, half-maximal inhibitory concentration: 310 nM
Compound 4: middle estimate off by 1.9-fold (0.29 log units), on the high side, and the stated range covers the measured number.
By their numbers in this assay, from the lowest: compounds 3 and 4 (each within the scatter of the next); then compound 1; then compound 2.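

In this assay, isopropyl in place of 4-chlorobutyl on a carbonyl carbon gives a 1.4-fold higher number from compound 3 to compound 4 (0.15 log units; within the scatter). This shows that neither the chlorine nor the unbranched chain of 4-chlorobutyl is required at this position for a number in this range, and that the branched isopropyl serves there as well. No supporting data bear on why the two groups read alike. The compounds shown leave open whether an amine, a carboxylic acid or a chain longer than 4-chlorobutyl would be accepted on this carbonyl carbon.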